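From prop-1-yn-1-yl to but-1-yn-1-yl: working notes

This account rests on a few compounds, and the source may have more. Where it says the series, first, only, none or still open, it means among the compounds named here.

- Compound 1 `Cc1cc2c(C(N)=O)cccc2n1-c1nc2c(c(NCc3ccccc3)n1)CCCC2`: 128 nM
- Compound 2 `CC#CC(=O)Nc1cccc2c1cc(C)n2-c1nc2c(c(NCc3ccccc3)n1)CCCC2`: 436 nM

In a functional assay on MIA PaCa-2 cells (Homo sapiens) for antiproliferative activity (a lower number here means that less compound is needed, a higher number that more compound is needed for the effect), compound 2, at 436 nM, has the higher of the two numbers. Compound 3 `CCC#CC(=O)Nc1cccc2c1cc(C)n2-c1nc2c(c(NCc3ccccc3)n1)CCCC2` differs from it by methyl in place of hydrogen on a saturated chain carbon bound to a triple-bonded carbon. Among the compounds with values here, the only measured step, a 3.4-fold higher number from compound 1 to compound 2 (0.53 log units; beyond the scatter), is a different change, with ((prop-1-yn-1-yl)carbonyl)amino in place of carbamoyl on an aromatic carbon. Within the data shown here, no measured step tests this chain, so no shift beyond the scatter is expected in this assay. For compound 3 the expected value is 450 nM, within an estimated range of 200 nM to 1000 nM. The estimated step is a 1.0-fold higher number from compound 2 to compound 3 (0.01 log units; within the scatter).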

Compound 3, half-maximal effective concentration in the MIA PaCa-2 assay: 463 nM
Beside the measured number, compound 3's estimate is 1.0-fold (0.01 log units) below it, within the range that was stated.
By their numbers in the MIA PaCa-2 assay, from the lowest: compound 1; then compounds 2 and 3 (each within the scatter of the next).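

In the MIA PaCa-2 assay, compound 2, with prop-1-yn-1-yl, gives 436 nM and compound 3, with but-1-yn-1-yl, gives 463 nM, within the scatter of each other (a 1.1-fold higher number from compound 2 to compound 3 (0.03 log units; within the scatter)), and the gap to the carbamoyl compound remains (a 3.6-fold higher number from compound 1 to compound 3 (0.56 log units; beyond the scatter)). In a physicochemical assay for pharmacokinetics, read by LC-MS, in phosphate buffer, tested at 1 uM (on this read-out lower numbers stand for a shorter-lived compound and higher numbers for a longer-lived compound), compound 2 gives 16.4 h and compound 3 gives 13.5 h, so the same change also stays within the scatter (a 1.2-fold lower number from compound 2 to compound 3 (0.08 log units; within the scatter)), and methyl in place of hydrogen on this saturated chain carbon shifts neither read-out beyond it. No evidence bears on this result. Still open, going by these compounds, is whether a longer chain, or an amine on this chain, would keep both read-outs in place.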